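A few compounds are considered here, and "the series" means these few. Any claim that something is new, unique, unknown or untested is made for them only; others in the source may bear on it.

Of the compounds shown here, two have so far been tested in a functional assay on the whole organism for inhibition, with Mus musculus as the target, at a dose of 25 mg/kg by the oral route; on this read-out higher numbers stand for more inhibition at the one dose given (going by the name of the read-out) and lower numbers for less inhibition. Compound 1 `Fc1cccc(N2CCN(CCCOc3ccc4c(c3)CCC4)CC2)c1` gives 19% in this assay, the lower of the two readings. Compound 2 `COc1ccccc1N1CCN(CCCCOc2ccc3c(c2)CCC3)CC1` gives 33% in this assay, a result that sits above compound 1 by more than the usual scatter. These two structures differ in more than one respect, so their values alone cannot be tied to any single change. The compound still to be measured is compound 3 `COc1ccc(N2CCN(CCCOc3ccc4c(c3)CCC4)CC2)cc1`, which differs from compound 1 by one change only: 4-methoxyphenyl in place of 3-fluorophenyl on an amine nitrogen in a ring. Among the measured compounds shown here, no pair of measured compounds isolates this change, so its effect is unknown and only a modest shift in either direction, or none beyond the scatter, can reasonably be anticipated. Compound 3 is therefore expected to give about 25% in this assay, with a plausible range from 8% to 45%. The expected step of a number 6 percentage points higher from compound 1 to compound 3 (within the scatter) lies within the scatter.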

Compound 3, a percentage reported as inhibition, in the whole organism at one dose (the size of the read-out at that dose, not a potency): 60%
Beside the measured number, compound 3's estimate is 35 percentage points below it; the whole stated range lies below it.
By their numbers in this assay, from the lowest: compound 1; then compound 2; then compound 3.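

In this assay, placing 4-methoxyphenyl instead of 3-fluorophenyl on the amine nitrogen in the ring gives a number 41 percentage points higher from compound 1 to compound 3 (beyond the scatter), a large step beyond the usual scatter. The rest of the molecule stays the same, so this one site on the shared core can strongly change the read-out at the single dose given. Nothing available explains the gain, and this single swap cannot separate the gain of the methoxy group from the loss of the fluorine atom.

From the compounds shown here alone, it remains open how this site would respond to other groups, such as a chlorine atom, a hydroxyl group or an ethoxy group in place of the methoxy group. With only one dose, the result also leaves open how the read-out would change at other doses.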